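Swapping the aniline ring on a full agonist core

This account rests on a few compounds, and the source may have more. Where it says the series, first, only, none or still open, it means among the compounds named here.

Measured compounds:
compound 1, `CC1(OC(=O)N2C[C@H]3COC[C@@H](C2)[C@@H]3Oc2ncnc(Nc3ccc(C#N)cc3Cl)c2F)CC1`: 99%
compound 2, `CC1(COC(=O)N2CC3COCC(C2)C3Oc2ncnc(Nc3ccc(C#N)cc3Cl)c2F)COC1`: 46%

Among the compounds with values here, only two compounds have a value in a functional assay for agonist activity at Glucose-dependent insulinotropic receptor (Mus musculus), read by cAMP accumulation; a lower number here means a smaller maximal response, a higher number a larger maximal response. Compound 1 stands highest of the two: in this assay compound 1 reaches 99%, while compound 2 reaches 46%, a gap that lies beyond the usual scatter. Compound 2 differs from compound 1 in more than one place, so no single change can be tied to that gap.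

Compound 3, `CC1(OC(=O)N2C[C@H]3COC[C@@H](C2)[C@@H]3Oc2ncnc(Nc3c(F)cccc3F)c2F)CC1`, has not been measured. It keeps the core of compound 1 and changes only the aryl group on the aromatic nitrogen: 2,6-difluorophenyl in place of 2-chloro-4-cyanophenyl on a nitrogen on an aromatic ring

Within the data shown here, no pair of measured compounds isolates a change of this kind, so the step is judged from compound 1 alone. Because compound 1 already sits at 99%, there is little room upward, and a change that removes the nitrile and the chlorine is expected to cost some maximal response. The step from compound 1 to compound 3 is therefore expected to be downward, beyond the scatter, at a number 29 percentage points lower from compound 1 to compound 3 (beyond the scatter). Compound 3 is estimated to give 70% in this assay, within a range of 35% to 100%.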

Compound 3, largest response reached (reported as percent of maximum), in percent of the reference or control that the assay uses: 108%
Compound 3: middle estimate off by 38 percentage points, on the low side; the whole stated range lies below it.
By their numbers in this assay, from the lowest: compound 2; then compounds 1 and 3 (each within the scatter of the next).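

In this assay, the step of a number 9 percentage points higher from compound 1 to compound 3 (within the scatter) shows that the 2-chloro-4-cyanophenyl group is not needed for a full maximal response at this position, on a nitrogen on an aromatic ring. The nitrile and the chlorine can both leave, and 2,6-difluorophenyl in their place gives a response that cannot be told apart from that of compound 1, so this aryl group accepts a more varied substitution than compound 1 alone could show. No measurement at hand accounts for this tolerance, and the read-out gives only the largest response reached, so it says nothing about how much compound is needed to reach it.

The compounds shown leave open whether a pyridine ring in place of the benzene ring, a methylsulfonyl group, or a single fluorine would hold the response on this nitrogen as well. From the compounds shown here alone, it also remains open whether 2,6-difluorophenyl would keep its response in the setting of compound 2, which gives 46% with the 2-chloro-4-cyanophenyl group.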